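Swapping the chain acid of compound 3 for hydroxyphenoxy

A few compounds are considered here, and "the series" means these few. Any claim that something is new, unique, unknown or untested is made for them only; others in the source may bear on it.

Compound 1 `COC(=O)c1ccccc1-c1ccc(CCc2ncc(CC(C)(C)C)n2CC(=O)O)cc1`: 968 nM
Compound 2 `COC(=O)c1c(F)cccc1-c1ccc(CCc2ncc(CC(C)(C)C)n2CCC(=O)O)cc1`: 1 nM
Compound 3 `CC(C)(C)Cc1cnc(CCc2ccc(-c3cccc(F)c3C(=O)O)cc2)n1CCC(=O)O`: 11 nM

In an assay on cells for agonist activity at Bombesin receptor subtype-3 (Homo sapiens), read by HTRF and inositol phosphate accumulation, with a stated time of 1 h (on this read-out lower numbers stand for an effect already at smaller amounts and higher numbers for an effect only at larger amounts of compound), compound 3 holds the second highest of the three numbers: compound 2 lies below it and compound 1 above it, each beyond the scatter. Compound 4 `CC(C)(C)Cc1cnc(CCc2ccc(-c3cccc(F)c3C(=O)O)cc2)n1CCOc1cccc(O)c1` differs from compound 3 by 3-hydroxyphenoxy in place of carboxy on a saturated chain carbon, two bonds along the chain from an aromatic nitrogen. Going by the values given here, the only measured single step, an 11-fold higher number from compound 2 to compound 3 (1.04 log units; beyond the scatter), concerns the methyl ester becoming an acid and leaves the chain end untouched; compound 1 and compound 2 differ in two places at once, so their two values alone can be read. Among the compounds with values here, no measured step bears on the present change, so the expectation rests on little. A somewhat higher number is expected, a 5.5-fold higher number from compound 3 to compound 4 (0.74 log units; beyond the scatter), with wide uncertainty. Compound 4 is estimated at 60 nM, between 8 nM and 500 nM.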

Compound 4, half-maximal effective concentration: 0.9 nM
For compound 4 the middle estimate is 67-fold (1.82 log units) above the measured one; the whole stated range lies above it.
By their numbers in this assay, from the lowest: compounds 4 and 2 (each within the scatter of the next); then compound 3; then compound 1.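

The carboxy group at this chain end is not required: in this assay the swap gives a 12-fold lower number from compound 3 to compound 4 (1.09 log units; beyond the scatter). This position therefore accepts a much larger group, with 8 heavy atoms and a six-membered aromatic ring in place of 3 heavy atoms and no ring. No measurement shown accounts for the gain. The compounds shown leave open whether the hydroxy on the new ring matters, which a plain phenoxy group would test. They also leave open whether an amine at this chain end would serve as well.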